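Swapping the Benzyl Arm for a Phenyl

The source may hold more compounds than are shown below. What is called first, only, known or untested is meant among the compounds shown, and "the series" means these compounds.

Compound 1: `CCOC(=O)c1ccc(-c2nn(Cc3cccc(OC)c3)c3ccccc23)cc1` — 260 nM
Compound 2: `CO/N=C\c1ccc(-c2nn(Cc3ccccc3)c3ccccc23)cc1` — > 10000 nM

Two compounds share the same core and were tested in a functional assay on cells (Platelet, Homo sapiens) for inhibition; a lower number here means a stronger inhibitor, a higher number a weaker inhibitor. Among the measured compounds shown here, compound 1 gives 260 nM and is the only compound of the pair with a proper number. For compound 2 the assay reports only a limit, > 10000 nM, and not a number; this is the situation described by the limit of > 10000 nM in this assay, at which 1 of the 2 values shown sits. For the measured compounds named here, because the two differ in more than one place, no single step between them is written down, and the values are stated here simply as they stand.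

Compound 3, `CCOC(=O)c1ccc(-c2nn(-c3ccccc3)c3ccccc23)cc1`, has not yet been measured. It differs from compound 1 in one place: phenyl in place of 3-methoxybenzyl on an aromatic nitrogen. Going by the values given here, with no measured step of this kind to lean on, the direction is open. The author expects the loss of the 3-methoxybenzyl group to cost some potency, so the step from compound 1 to compound 3 in this assay is estimated as a 2.5-fold higher number from compound 1 to compound 3 (0.40 log units; beyond the scatter). Compound 3 is accordingly expected to give 650 nM, with a range from 150 nM to 3000 nM.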

Compound 3, half-maximal inhibitory concentration: 2640 nM
The estimate for compound 3 lay 4.1-fold (0.61 log units) below the measured number; the range from low to high includes it.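

In this assay, among the compounds shown here, the group on the aromatic nitrogen now proves to matter, since the first one-place change at this position gives a 10-fold higher number from compound 1 to compound 3 (1.01 log units; beyond the scatter). Compound 3 still returns a proper number, 2640 nM, so a reading within the range of the assay survives the loss of the 3-methoxybenzyl arm, although the phenyl in its place gives up much of the potency held by compound 1. Nothing measured here accounts for the size of this step, and no property of either group has been given as a measured value.

The change replaces the whole arm at once, so the compounds shown do not separate the part played by the methoxy group from that of the carbon link joining the ring to the nitrogen; a plain benzyl group or a 3-hydroxybenzyl group on the ethyl ester core of compound 1 would divide the step into those two parts. As far as these compounds go, it also remains open whether a longer chain, such as 2-phenylethyl, or a 4-methoxybenzyl group would keep or exceed the potency of compound 1.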